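Swapping the acyl group on a threonine-derived amide

The source may report more compounds than this note shows. Statements on the series, on what has been measured and on what is new or still open speak of the compounds shown alone.

compound 1 `CCCCCCCCNC(=O)[C@@H](NC(=O)/C=C/c1ccccc1)[C@@H](C)O`: 41400 nM
compound 2 `CCCCCCCCCCCCCCNC(=O)[C@@H](NC(=O)c1nccc2ccccc12)[C@@H](C)O`: 21600 nM
compound 3 `CCCCCCCCCCCCCCNC(=O)[C@@H](NC(=O)c1cc2ccccc2[nH]1)[C@@H](C)O`: 14200 nM

These three compounds share one core and were tested in a functional assay on SiHa cells (Homo sapiens) for cytotoxicity, read by MTT assay, with a stated time of 48 h; on this read-out higher numbers stand for weaker inhibition and lower numbers for stronger inhibition. Compound 3 gives the lowest number of the three; its gap to compound 2 lies within the scatter, its gap to compound 1 beyond it. Compound 4 `CCCCCCCCCCCCCCNC(=O)[C@@H](NC(=O)/C=C/c1ccccc1)[C@@H](C)O` arises from compound 3 by 2-phenylethenyl in place of 1H-indol-2-yl on a carbonyl carbon. Within the data shown here, no measured step covers this exact swap. Among the measured compounds shown here, the only measured step, a 1.5-fold lower number from compound 2 to compound 3 (0.18 log units; within the scatter), exchanged one aromatic acyl group for another and stayed within the scatter. Compound 1 carries the same 2-phenylethenyl group as compound 4 but a shorter alkyl chain, and sits above compound 3 in this assay. For compound 4 the expected step is a 1.8-fold higher number from compound 3 to compound 4 (0.25 log units; within the scatter), a somewhat higher number still close to compound 3. The estimate for compound 4 is 25000 nM, expected between 8000 nM and 80000 nM.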

Compound 4, half-maximal inhibitory concentration: 35800 nM
The estimate for compound 4 lay 1.4-fold (0.16 log units) below the measured number, within the range that was stated.
By their numbers in this assay, from the lowest: compounds 3, 2, 4 and 1 (each within the scatter of the next, the first and the last beyond it).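

In this assay the acyl group at this carbonyl carbon now gives a step beyond the scatter (a 2.5-fold higher number from compound 3 to compound 4 (0.40 log units; beyond the scatter)), while replacing isoquinolin-1-yl with 2-phenylethenyl stays within it (a 1.7-fold higher number from compound 2 to compound 4 (0.22 log units; within the scatter)). With 2-phenylethenyl in place, adding hexyl to the alkyl chain also stays within the scatter (a 1.2-fold lower number from compound 1 to compound 4 (0.06 log units; within the scatter)). Nothing here explains why 1H-indol-2-yl and 2-phenylethenyl differ.

Going by these compounds, whether that difference persists on the shorter chain of compound 1 remains open. So does the outcome of placing an amine or a carboxylic acid on the acyl group.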